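The compounds below may be only part of what the source reports. "The series", "measured", "known", "first", "only" and "open" are said of these compounds alone.

Compound 1 `CO/N=C(\C)c1ccc(Sc2cc(F)cc(C3CCOCC3)c2)cc1` is the reference point of this account. In a functional assay (blood) for inhibition, with Homo sapiens as the target (a higher number here means a weaker inhibitor, a lower number a stronger inhibitor), compound 1 gives 110 nM. Of the three compounds measured, compound 1 has no number beneath it: compound 3 `C/C(=N\OCC(O)CO)c1ccc(S(=O)(=O)c2cccc(C3CCOCC3)c2)cc1` gives 160 nM, a gap that lies within the usual scatter, whereas compound 2 `C/C(=N\OCc1ccncc1)c1ccc(Sc2cc(F)cc(C3CCOCC3)c2)cc1` gives 300 nM, and the step of a 2.7-fold higher number from compound 1 to compound 2 (0.44 log units; beyond the scatter) is modest but beyond the scatter. Compound 4 `CC(=O)/C(=N\O)c1ccc(Sc2cc(F)cc(C3CCOCC3)c2)cc1` has not yet been measured in this assay. It differs from compound 1 by a group of 6 heavy atoms (3 carbon, 1 nitrogen, 2 oxygen; no ring) in place of a group of 5 heavy atoms (3 carbon, 1 nitrogen, 1 oxygen; no ring), on an aromatic carbon. Going by the values given here, the single measured step alters the substituent on a saturated chain carbon bound to an oxygen, not the group on the aromatic carbon itself, so none of the measured steps bears directly on this change; the value of compound 1 is the only anchor. Among the compounds with values here, with no direct precedent, the expectation for compound 4 is a step of a 2.3-fold higher number from compound 1 to compound 4 (0.36 log units; beyond the scatter), at most a modest weakening. Compound 4 is therefore estimated at 250 nM in this assay, with a range from 80 nM to 800 nM.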

Compound 4, half-maximal inhibitory concentration: 850 nM
Estimate against measurement, compound 4: 3.4-fold (0.53 log units) below; measured number outside the range, above it.
By their numbers in this assay, from the lowest: compounds 1, 3 and 2 (each within the scatter of the next, the first and the last beyond it); then compound 4.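

The group on the aromatic carbon, para to a large group, turns out to matter: in this assay replacing it gives a 7.7-fold higher number from compound 1 to compound 4 (0.89 log units; beyond the scatter), and compound 4 stands above all three earlier compounds. This step is larger than a 2.7-fold higher number from compound 1 to compound 2 (0.44 log units; beyond the scatter), which concerned a saturated chain carbon bound to an oxygen, so this position responds at least as strongly as the only other site changed in one place. The group that enters has 1 hydrogen-bond donor and 2 double bonds outside aromatic rings, against 0 hydrogen-bond donors and 1 such double bond in the group that leaves, and nothing shown says which of these differences carries the loss.

The compounds shown leave open how an amine, a carboxylic acid or a longer chain would fare on this aromatic carbon. They also leave open whether the same change would cost as much on the core of compound 3.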